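Second fluoro on the fused ring of compound 1

The source may report more compounds than this note shows. Statements on the series, on what has been measured and on what is new or still open speak of the compounds shown alone.

Compound 1, `CCC(Nc1nnc(-c2ccc(OC)cc2)o1)[C@H]1CC[C@@H](c2ccnc3ccc(F)cc32)CC1`, gives 16 nM in an assay on blood for inhibition of Indoleamine 2,3-dioxygenase 1 (Homo sapiens), read by mass spectrometry, with a stated time of 18 h; on this read-out higher numbers stand for weaker inhibition and lower numbers for stronger inhibition. Of the three numbers in hand it stands lowest. Compound 2, `C[C@@H](c1nc2ccc(Cl)cc2[nH]1)[C@H]1CC[C@@H](c2ccnc3ccc(F)cc32)CC1`, gives 32 nM in this assay, and its gap to compound 1 lies within the scatter, so the two cannot be ordered. Compound 3, `CCC(c1nc2ccc(Cl)cc2[nH]1)[C@H]1CC[C@H](Oc2ccnc3ccccc23)CC1`, gives 36 nM in this assay, which sits beyond the scatter from compound 1. Among the measured compounds shown here, no step between measured compounds that differ in a single place is available, so no measured change informs the next move directly.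

Compound 4, `CCC(Nc1nnc(-c2ccc(OC)cc2)o1)[C@H]1CC[C@@H](c2ccnc3c(F)cc(F)cc32)CC1`, differs from compound 1 by fluoro in place of hydrogen on an aromatic carbon. The fluoro enters on an aromatic carbon of the six-membered carbon ring of the fused system, meta to the fluoro already present. With nothing measured for such a change in this series, the step is expected to be small, in either direction or none beyond the scatter, and the expected step is a 1.1-fold higher number from compound 1 to compound 4 (0.05 log units; within the scatter). Compound 4 is therefore estimated at 18 nM in this assay, with a range from 7 nM to 45 nM.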

Compound 4, half-maximal inhibitory concentration: 14 nM
For compound 4 the middle estimate is 1.3-fold (0.11 log units) above the measured one, and the stated range covers the measured number.
By their numbers in this assay, from the lowest: compounds 4, 1, 2 and 3 (each within the scatter of the next, the first and the last beyond it).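

Among the compounds shown here, this is the first step that differs in a single place. In (this assay), fluoro in place of hydrogen on an aromatic carbon of the fused system, meta to the fluoro group already present, gives (a 1.1-fold lower number from compound 1 to compound 4 (0.06 log units; within the scatter)), so compound 1 and compound 4 cannot be ordered, and this position accepts the added fluoro without a readable loss in this read-out. No independent data bear on this result.

As far as these compounds go, whether the same position would hold its number with chloro, methoxy or an amine in place of fluoro remains open. Also open, from the compounds shown here alone, is whether fluoro on the other aromatic carbons of this ring would behave in the same way.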